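Swapping One Aromatic Group on a Shared Core

The source may report more compounds than this note shows. Statements on the series, on what has been measured and on what is new or still open speak of the compounds shown alone.

Three measured compounds share one core and carry different aromatic groups on a saturated ring carbon: compound 1 `N#Cc1ccc(C2OCC(C/C=C\CCC(=O)O)C(c3cccnc3)O2)cc1`, compound 2 `O=C(O)CC/C=C\CC1COC(c2ccc([N+](=O)[O-])cc2)OC1c1cccnc1` and compound 3 `O=C(O)CC/C=C\CC1COC(c2ccc(Cl)cc2Cl)OC1c1cccnc1`. In a functional assay for inhibition, with Homo sapiens as the target (on this read-out lower numbers stand for tighter binding and higher numbers for weaker binding), compound 1 gives 1290 nM, compound 2 gives 933 nM and compound 3 gives 891 nM. Compound 3 therefore stands level with the other two, as its gaps to both lie within the usual scatter of repeated measurements.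

The next compound to be tested is compound 4 `O=C(O)CC/C=C\CC1COC(c2ccc(C(F)(F)F)cc2)OC1c1cccnc1`. It carries 4-(trifluoromethyl)phenyl in place of 2,4-dichlorophenyl on a saturated ring carbon, between two ring oxygen atoms: 4-(trifluoromethyl)phenyl in place of 2,4-dichlorophenyl on a saturated ring carbon.

Going by the values given here, three measured steps bear on this swap, as all of them alter the same aromatic group. Going by a 1.4-fold lower number from compound 1 to compound 3 (0.16 log units; within the scatter), a 1.0-fold lower number from compound 2 to compound 3 (0.02 log units; within the scatter) and a 1.4-fold lower number from compound 1 to compound 2 (0.14 log units; within the scatter), all within the scatter, no step beyond the scatter is expected in this assay. The expected change is small, and the estimated step is a 1.1-fold higher number from compound 3 to compound 4 (0.05 log units; within the scatter). Among the compounds with values here, no measured compound carries a trifluoromethyl group, and three compounds are a thin basis, so the expected range is kept wide. The estimate for compound 4 is 1000 nM, with an expected range from 550 nM to 1800 nM.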

Compound 4, dissociation constant: 1780 nM
Compound 4: middle estimate off by 1.8-fold (0.25 log units), on the low side; the range from low to high includes it.
By their numbers in this assay, from the lowest: compounds 3, 2, 1 and 4 (each within the scatter of the next).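

Placing 4-(trifluoromethyl)phenyl on the saturated ring carbon between two ring oxygen atoms gives a 2.0-fold higher number from compound 3 to compound 4 (0.30 log units; within the scatter), a 1.9-fold higher number from compound 2 to compound 4 (0.28 log units; within the scatter) and a 1.4-fold higher number from compound 1 to compound 4 (0.14 log units; within the scatter). This position in this assay has now taken a fourth aromatic group, the first to carry fluorine, and all four compounds remain level with one another, even though the step from the 2,4-dichlorophenyl group is the widest of the three new ones. Nothing measured here accounts for the size of these steps.

The compounds shown leave open whether an amine or a hydroxyl group on the phenyl ring, or a cyclohexyl group in its place, would give a step beyond the scatter. They also leave open what a change to the pyridin-3-yl group or the 5-carboxypent-2-en-1-yl group would do, since these two groups stay the same in all four compounds.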